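Swapping the Chain on a Peroxide Core

A few compounds are considered here, and "the series" means these few. Any claim that something is new, unique, unknown or untested is made for them only; others in the source may bear on it.

Compound 2 `NCCS(=O)(=O)CCOc1ccc([C@H]2CC[C@]3(CC2)OOC2(O3)C3CC4CC(C3)CC2C4)cc1` was tested in an ADME assay on microsomes from liver (Homo sapiens) for metabolic stability, read by LC-MS, tested at 1 uM (on this read-out lower numbers stand for slow clearance and higher numbers for fast clearance), and gave 9 mL.min-1.g-1. Among the compounds with values here, its only measured neighbour, compound 1 `CC(C)(O)CN1CCC(Oc2ccc([C@H]3CC[C@]4(CC3)OOC3(O4)C4CC5CC(C4)CC3C5)cc2)CC1`, gave 18 mL.min-1.g-1 in this assay, and the step of a 2.0-fold lower number from compound 1 to compound 2 (0.30 log units; within the scatter) came from replacing part of the side chain. Compound 3 `O[C@H]1CC[C@H](NCCCOc2ccc([C@H]3CC[C@]4(CC3)OOC3(O4)C4CC5CC(C4)CC3C5)cc2)CC1` differs from compound 2 by ((4-hydroxycyclohexyl)amino)methyl in place of (2-aminoethyl)sulfonyl on a saturated chain carbon, two bonds along the chain from an oxygen on an aromatic ring. Within the data shown here, the one measured step does not touch this kind of change and was itself small, so little guidance exists. A modest step of a 1.6-fold higher number from compound 2 to compound 3 (0.19 log units; within the scatter) is expected, not clearly beyond the scatter. Compound 3 is therefore expected to give 14 mL.min-1.g-1, with a range from 6 mL.min-1.g-1 to 35 mL.min-1.g-1.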

Compound 3, intrinsic clearance in microsomes: < 7 mL.min-1.g-1
Compound 3: a limit, no number (the forecaster's own chance of this, stated with the estimate: 5%); middle value at least 2.0-fold (0.30 log units) from the limit.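

In this assay compound 3 gives < 7 mL.min-1.g-1, which is a limit of the assay and not a number. Even so, an at least 2.5-fold lower number from compound 1 to compound 3 (0.41 log units; beyond the scatter) is the first step here to pass beyond the scatter, so 3-((4-hydroxycyclohexyl)amino)propyl on an oxygen on an aromatic ring gives slower clearance than the side chain of compound 1. The other step, an at least 1.2-fold lower number from compound 2 to compound 3 (0.10 log units; that floor lies within the scatter), cannot separate compound 3 from compound 2.

Going by these compounds, the true size of both steps stays open because compound 3 is known only as a limit: the limit of < 7 mL.min-1.g-1 in this assay, at which 1 of the 3 values shown sits. On these data alone, how a carboxylic acid or a longer chain would behave at this position also remains open.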